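A few compounds are considered here, and "the series" means these few. Any claim that something is new, unique, unknown or untested is made for them only; others in the source may bear on it.

Measured so far in a functional assay on A549 cells (Homo sapiens) for antiproliferative activity, read by MTT assay, with a stated time of 72 h; on this read-out higher numbers stand for weaker inhibition and lower numbers for stronger inhibition:
- compound 1, `c1ccc(COc2ccccc2Nc2ncnc3cc4c(cc23)OCCOCCO4)cc1`: > 100000 nM
- compound 2, `O=[N+]([O-])c1ccc(COc2ccc(Nc3ncnc4cc5c(cc34)OCCOCCO5)cc2)cc1`: 8620 nM
- compound 3, `c1ccc(COc2ccccc2Nc2ncnc3cc4c(cc23)OCCOCCOCCO4)cc1`: 6940 nM

Compound 1 gives only a limit of the assay, (the limit of > 100000 nM in this assay, at which 1 of the 3 values shown sits), and no number. Compound 2 and compound 3 are the two compounds with numbers; the gap between them is within the scatter, so neither is set apart from the other. Compound 2 thus stands among the two numbers shown without a meaningful separation from compound 3.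

The open question is compound 4, `c1ccc(COc2ccc(Nc3ncnc4cc5c(cc34)OCCOCCO5)cc2)cc1`, which is not yet measured in this assay. It differs from compound 2 by hydrogen in place of nitro on an aromatic carbon. Among the measured compounds shown here, no measured pair covers this change, so there is no direct guide to its size or direction. With nothing to point either way, the expectation is a step of no more than the scatter in either direction, the nitro group leaving without a large shift.

Compound 4 is expected to give an estimate of 10000 nM, with a range from 3000 nM to 40000 nM. The expected step is a 1.2-fold higher number from compound 2 to compound 4 (0.06 log units; within the scatter).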

Compound 4, half-maximal inhibitory concentration: 43900 nM
Estimate against measurement, compound 4: 4.4-fold (0.64 log units) below; measured number above the stated range.
By their numbers in this assay, from the lowest: compounds 3 and 2 (each within the scatter of the next); then compound 4. At a limit, above all of these: compound 1.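

In this assay, removing nitro from the aromatic carbon para to a large group gives a 5.1-fold higher number from compound 2 to compound 4 (0.71 log units; beyond the scatter), so this position does respond to the change. Among the compounds shown here, this is the first pair that differs in one place, and it shows that the 4-nitrobenzyl compound gives the stronger inhibition of the two, though nothing here measures a property of the nitro group that would account for the step. Compound 1 remains the only compound at a limit of the assay, which is not a number: the limit of > 100000 nM in this assay, at which 1 of the 4 values shown sits.

From the compounds shown here alone, whether the step is specific to nitro stays open, as an amine, a nitrile or a carboxylic acid at the same place would test that. Also open, going by these compounds, is whether the same change carries over to the core of compound 3.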